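The source may hold more compounds than are shown below. What is called first, only, known or untested is meant among the compounds shown, and "the series" means these compounds.

Among the compounds with values here, in a functional assay on MOLT-4 cells (Homo sapiens) (on this read-out higher numbers stand for weaker inhibition and lower numbers for stronger inhibition), compound 1 `OC[C@H]1C[C@@H](Cn2cnc3c(O)ncnc32)c2ccccc21` gives 24 ug/mL and compound 2 `CC(C)Nc1ncnc2c1ncn2C[C@@H]1C[C@H](CO)c2ccccc21` gives 24 ug/mL, so compound 2 stands level with its only measured neighbour. Compound 3 `OC[C@H]1C[C@@H](Cn2cnc3c(NC4CC4)ncnc32)c2ccccc21` differs from compound 2 in one place, with cyclopropyl in place of isopropyl on a nitrogen on an aromatic ring. Within the data shown here, the one measured step that bears on this, isopropylamino in place of hydroxy, shows no change at the digits printed from compound 1 to compound 2 (within the scatter). That single step gives no reason to expect a shift beyond the scatter in this assay, in either direction. The expected step is no change at the digits printed from compound 2 to compound 3 (within the scatter). For compound 3 the estimated value is 24 ug/mL, with an expected range of 12 ug/mL to 48 ug/mL.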

Compound 3, half-maximal inhibitory concentration: 24 ug/mL
Compound 3: middle estimate and measured number agree at the digits printed, within the range that was stated.
By their numbers in this assay, from the lowest: compounds 1, 2 and 3 (each within the scatter of the next).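

In this assay there is no change at the digits printed from compound 2 to compound 3 (within the scatter) when cyclopropyl takes the place of isopropyl on this nitrogen, so adding a three-membered ring of carbon while keeping the same count of heavy atoms leaves the reading flat. Cyclopropylamino in place of hydroxy on the aromatic carbon also gives no change at the digits printed from compound 1 to compound 3 (within the scatter) in this comparison, making it a second amino group that reads level with hydroxy. Nothing measured here explains these flat readings. Still open, as far as these compounds go, is whether a larger group on this nitrogen, such as benzyl or a longer chain like n-butyl, would move the value. From the compounds shown here alone, a plain unsubstituted amine at the same aromatic carbon is equally open.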